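Removing a chloro group in a paw edema assay

The source may report more compounds than this note shows. Statements on the series, on what has been measured and on what is new or still open speak of the compounds shown alone.

Of the compounds shown here, three have been tested in a functional assay on the whole organism (strain Wistar) for inhibition, with Rattus norvegicus as the target, read by paw edema, with stated times of 2 h and 1 h, at a dose of 6 mg/kg by the oral route; a lower number here means less inhibition, a higher number more inhibition at the dose given (going by the name of the read-out). Compound 1 `O=C(CO[N+](=O)[O-])NNC(=O)c1ccc(-n2[nH]c(=O)cc2-c2ccc(Cl)cc2)cc1` gives 11.5% in this assay. Compound 2 `O=C(CO[N+](=O)[O-])NNC(=O)c1ccc(-n2[nH]c(=O)cc2-c2ccccc2)cc1` differs from compound 1 only by hydrogen in place of chloro on an aromatic carbon. In this assay compound 2 gives 16.1%; the step is a number 4.6 percentage points higher from compound 1 to compound 2 (within the scatter), so the two numbers are indistinguishable here. Compound 3 `CCOC(=O)c1c(-c2ccc(Cl)cc2)n(-c2ccc(C(=O)NNC(=O)CO[N+](=O)[O-])cc2)[nH]c1=O` carries a different core from compound 1, the difference being (ethoxycarbonyl in place of hydrogen on an aromatic carbon). In this assay compound 3 gives 10.4%, and the step is a number 1.1 percentage points lower from compound 1 to compound 3 (within the scatter), again within the scatter. All three numbers therefore sit close together, and none of the compounds can be said to give a higher or lower number than another.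

Compound 4 `CCOC(=O)c1c(-c2ccccc2)n(-c2ccc(C(=O)NNC(=O)CO[N+](=O)[O-])cc2)[nH]c1=O` has not yet been measured. It is related to compound 3 by hydrogen in place of chloro on an aromatic carbon, and this is the same change that separates compound 1 from compound 2, made on the same place of the ring. Because that earlier step was a number 4.6 percentage points higher from compound 1 to compound 2 (within the scatter), the expectation is that the step from compound 3 to compound 4 will also be small, estimated as a number 4.1 percentage points higher from compound 3 to compound 4 (within the scatter). On that basis compound 4 is expected to give about 14.5% in this assay, with the estimate spanning from 4% to 25%. This rests on a single prior example of the change, so the estimate is loose.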

Compound 4, a percentage reported as inhibition, in the whole organism at one dose (the size of the read-out at that dose, not a potency): 57.8%
The estimate for compound 4 lay 43.3 percentage points below the measured number, and the stated range ends below it.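

In this assay, the change from 4-chlorophenyl to phenyl gives a number 47.4 percentage points higher from compound 3 to compound 4 (beyond the scatter), and set beside the earlier case of the same change, the two steps clearly disagree: the same change on two cores in this assay, a number 4.6 percentage points higher (within the scatter) from compound 1 to compound 2 and a number 47.4 percentage points higher (beyond the scatter) from compound 3 to compound 4, 42.8 percentage points apart, beyond the scatter of two such steps

Read the other way, ethoxycarbonyl in place of hydrogen gives a number 41.7 percentage points higher from compound 2 to compound 4 (beyond the scatter), and this too fails to match its earlier counterpart: the same change on two cores in this assay, a number 1.1 percentage points lower (within the scatter) from compound 1 to compound 3 and a number 41.7 percentage points higher (beyond the scatter) from compound 2 to compound 4, 42.8 percentage points apart, beyond the scatter of two such steps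

So neither change carries a fixed step from one core to another in this series, and the large number appears only in compound 4, which has the ethoxycarbonyl group and lacks the chloro group, but this rests on one set of four compounds at a single dose and does not show why the two changes work together or whether the same would hold for other groups.

Going by these compounds, it remains open whether a fluoro or methoxy group in place of the chloro would behave like hydrogen on the core of compound 4. On these data alone, it is also open whether a carboxylic acid or a primary amide in place of the ethoxycarbonyl group would keep the large number seen with compound 4.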